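Losing the dimethylamino group from compound 1

The source may hold more compounds than are shown below. What is called first, only, known or untested is meant among the compounds shown, and "the series" means these compounds.

Going by the values given here, in a functional assay on HeLa cells (Homo sapiens) for antiproliferative activity, read by MTT assay, with a stated time of 48 h (a lower number here means a stronger inhibitor of growth, a higher number a weaker inhibitor of growth), compound 1 `Cc1cc2c(c(=O)n1C)C(c1ccc(N(C)C)c(Br)c1)C(C#N)=C(N)O2` gives 330 nM, the higher of the two actual numbers measured so far. The nearest value belongs to compound 2 `COc1cc(C2C(C#N)=C(N)Oc3cc(N(C)C)ccc32)cc(OC)c1OC`, at 17 nM, a lower number by a margin beyond the scatter. Compound 3 `Cc1cc2c(c(=O)o1)C(c1cccc(Br)c1)C(C#N)=C(N)O2` gives > 100000 nM, which is a limit of the assay and not a number.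

The next compound to be tested in this assay is compound 4 `Cc1cc2c(c(=O)n1C)C(c1cccc(Br)c1)C(C#N)=C(N)O2`. It has hydrogen in place of the dimethylamino of compound 1, on an aromatic carbon of a six-membered aromatic ring of carbon only, ortho to a bromo group and para to a large group: hydrogen in place of dimethylamino on an aromatic carbon.

Among the compounds with values here, no step between measured compounds isolates this change, so its size can only be judged indirectly. The expectation leans on compound 3, which holds no dimethylamino group and gives > 100000 nM. A move to a higher number, meaning a weaker inhibitor of growth, is therefore expected, and it should lie beyond the scatter. The estimated change is a 9.1-fold higher number from compound 1 to compound 4 (0.96 log units; beyond the scatter). Compound 4 is expected to give about 3000 nM. The estimated range for that value runs from 600 nM to 20000 nM.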

Compound 4, concentration for 50% growth inhibition: 6500 nM
Beside the measured number, compound 4's estimate is 2.2-fold (0.34 log units) below it; low and high end bracket the measured number.
By their numbers in this assay, from the lowest: compound 2; then compound 1; then compound 4. At a limit, above all of these: compound 3.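

In this assay, replacing the dimethylamino group with hydrogen on this aromatic carbon, ortho to a bromo group and para to a large group, gives a 20-fold higher number from compound 1 to compound 4 (1.29 log units; beyond the scatter), a large step. Going by these compounds alone, the earlier compounds offered no pair differing in this one place, so this is the first direct reading of the change, and it shows that compound 4 still gives a measured number rather than a limit. Compound 3, which has no dimethylamino group either, gives a limit of the assay and not a number: the limit of > 100000 nM in this assay, at which 1 of the 4 values shown sits.

Going by these compounds, it remains open whether a smaller amine such as methylamino, a cyclic amine such as morpholine or an ether such as methoxy at this position would hold the number of compound 1 or follow compound 4. Also unresolved is how far the step depends on the neighbouring bromo group, which chloro in its place could test, and whether removing the dimethylamino group from a different part of the structure, as found in compound 2, would cost as much.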